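Dimethylamino for fluoro: from compound 2 to compound 4

The source may hold more compounds than are shown below. What is called first, only, known or untested is meant among the compounds shown, and "the series" means these compounds.

Measured so far in an in vitro functional assay on HEK285-7 cells for antagonist activity at prostaglandin D2 receptor 2 (Homo sapiens), read by BRET and beta-arrestin recruitment; a lower number here means a smaller maximal response, a higher number a larger maximal response:
compound 1 `O=C(O)Cc1sc(CS(=O)(=O)c2ccc(Cl)cc2)nc1-c1ccc(Cl)cc1` gives 30%
compound 2 `O=C(O)Cc1sc(C(c2ccc(F)cc2)c2ccc(F)cc2)nc1-c1ccnc(F)c1` gives 80%
compound 3 `O=C(O)Cc1sc(NC(=O)c2ccccc2)nc1-c1ccc(Cl)cc1` gives 50%

Compound 2 stands highest of the three numbers in this assay. Compound 3 is its nearest neighbour, and the gap between the two lies beyond the scatter. Compound 1 is furthest from compound 2, again beyond the scatter. Going by the values given here, no pair among the measured compounds differs in a single place, so no measured step is available as a guide.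

Compound 4 `CN(C)c1cc(-c2nc(C(c3ccc(F)cc3)c3ccc(F)cc3)sc2CC(=O)O)ccn1` is the next compound to go into this assay. It differs from compound 2 in one place: dimethylamino in place of fluoro on an aromatic carbon. Fluoro leaves and dimethylamino enters on an aromatic carbon of a six-membered aromatic ring with one nitrogen, next to the ring nitrogen; seen one bond further out, 2-fluoropyridin-4-yl becomes 2-(dimethylamino)pyridin-4-yl. With nothing measured for this change, the expectation is a modest step, at most just beyond the scatter and more likely downward than upward, giving a number 10 percentage points lower from compound 2 to compound 4 (within the scatter). Compound 4 is therefore estimated at 70%, with a range from 45% to 95%.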

Compound 4, largest response reached (reported as efficacy), in percent of the reference or control that the assay uses: 80%
The estimate for compound 4 lay 10 percentage points below the measured number, and the stated range covers the measured number.
By their numbers in this assay, from the lowest: compound 1; then compound 3; then compounds 2 and 4 (each within the scatter of the next).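

In this assay, dimethylamino in place of fluoro gives no change at the digits printed from compound 2 to compound 4 (within the scatter) as the only single-place step among the compounds shown. At this aromatic carbon next to the ring nitrogen, a single fluorine atom and a group of three heavy atoms carrying a hydrogen-bond acceptor are therefore not separated by the maximal response, so the position accepts this larger group in this one comparison. No available evidence bears on this outcome.

Still open, from the compounds shown here alone, is how the same position responds to a primary amine, a methoxy group or a morpholine ring, and whether a longer chain on the amine nitrogen, such as diethylamino, leaves the read-out equally unmoved. One step on one scaffold also leaves open whether the result carries over when the bis(4-fluorophenyl)methyl group is replaced.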